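The source may hold more compounds than are shown below. What is called first, only, known or untested is meant among the compounds shown, and "the series" means these compounds.

Measured compounds:
- compound 1 `CCCCNc1nc(N)nc(C)c1CCCCO` — in an assay on HEK293 cells for agonist activity at Toll-like receptor 8 (Homo sapiens), read by spectrophotometry (on this read-out higher numbers stand for an effect only at larger amounts of compound and lower numbers for an effect already at smaller amounts), compound 1 gives 1310 nM here
- compound 2 `CCCCNc1nc(N)nc(C)c1CCCN1CCCCC1` — compound 2 gives 133 nM here
- compound 3 `CCCCNc1nc(N)nc(C)c1CC` — compound 3 gives 1660 nM here

Compound 3 carries the highest number of the three; to compound 1 the gap is within the scatter, while compound 2 sits apart, with a 12-fold higher number from compound 2 to compound 3 (1.10 log units; beyond the scatter) marking the distance. The step of a 9.8-fold lower number from compound 1 to compound 2 (0.99 log units; beyond the scatter) shows the same thing from the other side, and a 1.3-fold higher number from compound 1 to compound 3 (0.10 log units; within the scatter) shows that trimming the chain to an ethyl costs nothing resolvable.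

Compound 4 `CCCCNc1nc(N)nc(C)c1CCc1ccccc1` is the next member. The change is phenyl in place of hydrogen on a saturated chain carbon, two bonds along the chain from an aromatic carbon and it adds a hydrocarbon ring with no donor or acceptor. Among the compounds with values here, none of the measured steps contains this ring; the only step beyond the scatter, from compound 2 onward, rests on a group with a nitrogen, and the hydroxyethyl-to-hydrogen step was flat. The phenyl is therefore expected to give a small step in this assay, with the direction uncertain and the estimate leaning toward a slightly lower number, a 1.8-fold lower number from compound 3 to compound 4 (0.27 log units; within the scatter) being the expected size. Compound 4 is estimated at 900 nM in this assay, with an expected range from 250 nM to 3500 nM around it.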

Compound 4, half-maximal effective concentration: 1190 nM
The estimate for compound 4 lay 1.3-fold (0.12 log units) below the measured number; the range from low to high includes it.
By their numbers in this assay, from the lowest: compound 2; then compounds 4, 1 and 3 (each within the scatter of the next).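

In this assay, phenyl in place of hydrogen on a saturated chain carbon, two bonds along the chain from an aromatic carbon, brings in six heavy atoms and a six-membered aromatic ring of carbon only, yet the result is a 1.4-fold lower number from compound 3 to compound 4 (0.14 log units; within the scatter), so at this position a group of that size does not by itself give a resolvable step. The comparison with the hydroxyl-bearing chain reads the same way, with a 1.1-fold lower number from compound 1 to compound 4 (0.04 log units; within the scatter), which places ethyl, the hydroxyl-bearing chain and the phenyl-bearing chain within the scatter of one another despite their different end groups. Within the data shown here, compound 2 stays apart from this cluster, with an 8.9-fold higher number from compound 2 to compound 4 (0.95 log units; beyond the scatter), so a ring at the chain end is not enough to match it: of the two ring-bearing compounds, only the one whose ring is piperidine, with its nitrogen, stands apart, and compound 4 does not.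

From the compounds shown here alone, whether the nitrogen or the saturated ring of compound 2 carries the step stays open, and a dimethylamino group, a morpholine ring, a carboxylic acid or a longer chain ending in phenyl at this position would each bear on that question. Nothing shown here gives a reason for any of these steps.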